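The source may report more compounds than this note shows. Statements on the series, on what has been measured and on what is new or still open speak of the compounds shown alone.

Measured so far in an assay on isolated protein with Bile acid receptor (Homo sapiens) as the target; a lower number here means that less compound is needed, a higher number that more compound is needed for the effect: compound 1 `COC(=O)/C=C/c1cccc(N(Cc2ccc(/C=C/c3cccc(F)c3)cc2)C(=O)C2CCCCC2)c1` gives 86 nM; compound 2 `COC(=O)/C=C/c1cccc(N(Cc2ccc(/C=C/c3cccc(F)c3)cc2)C(=O)C(C)C)c1` gives 71 nM; compound 3 `COC(=O)/C=C/c1cccc(N(Cc2ccc(/C=C/c3ccc(F)cc3)cc2)C(=O)NC(C)C)c1` gives 348 nM.

Compound 1 holds the second highest of the three numbers, nearest to compound 2 (a 1.2-fold lower number from compound 1 to compound 2 (0.08 log units; within the scatter), within the scatter) and furthest from compound 3, whose number lies beyond the scatter from it. Compound 4 `COC(=O)/C=C/c1cccc(N(Cc2ccc(-c3cccc(C)c3)cc2)C(=O)C2CCCCC2)c1` differs from compound 1 in one place: 3-methylphenyl in place of 2-(3-fluorophenyl)ethenyl on an aromatic carbon. For the measured compounds named here, the only measured single step, from compound 1 to compound 2, sits on the carbonyl carbon and does not touch the group exchanged here, so no measured pair bears directly on this change. Compound 3 differs from compound 1 in two places, so its gap says nothing about this step alone. For compound 4 a modest rise in this assay is expected, a 2.3-fold higher number from compound 1 to compound 4 (0.37 log units; beyond the scatter), giving an estimate of 200 nM (range 60 nM to 700 nM).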

Compound 4, half-maximal effective concentration: 109 nM
Beside the measured number, compound 4's estimate is 1.8-fold (0.26 log units) above it; the range from low to high includes it.
By their numbers in this assay, from the lowest: compounds 2, 1 and 4 (each within the scatter of the next); then compound 3.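

In this assay, the aromatic carbon para to a large group takes 3-methylphenyl in place of 2-(3-fluorophenyl)ethenyl with a 1.3-fold higher number from compound 1 to compound 4 (0.10 log units; within the scatter) and so stays within the scatter. This exchange removes the double bond outside aromatic rings and the fluorine together, and the number holds even with the smaller group. No measurement on hand offers an explanation for this result.

The separate contributions of the double bond and of the exchange of fluorine for methyl remain unresolved. Also open, going by these compounds, is how an amine or a carboxylic acid on this aromatic ring would read.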